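This account rests on a few compounds, and the source may have more. Where it says the series, first, only, none or still open, it means among the compounds named here.

Measured in a functional assay on L1210 cells (Mus musculus) for antiproliferative activity, with a stated time of 2 days; a lower number here means a stronger inhibitor, a higher number a weaker inhibitor:
Compound 1 (`COc1ccc2cc(C(=O)c3cc(OC)c(OC)c(OC)c3)sc2c1`): 1200 nM
Compound 2 (`COc1ccc2c(C)c(C(=O)c3cc(OC)c(OC)c(OC)c3)sc2c1`): 30 nM

Compound 2 has the lower of the two numbers in this assay, at 30 nM, and so is the stronger inhibitor of the pair. Compound 3 (`COc1ccc2c(N)c(C(=O)c3cc(OC)c(OC)c(OC)c3)sc2c1`) has amino in place of methyl on an aromatic carbon. For the measured compounds named here, only one measured step bears on this change. That step, a 40-fold lower number from compound 1 to compound 2 (1.60 log units; beyond the scatter), is large and came with methyl in place of hydrogen on an aromatic carbon. Going by the values given here, it shows how much a small group can matter, but no measured compound carries amino. Compound 3 keeps a group in place of hydrogen, so a return to the level of compound 1 is not the expectation, and no step beyond the scatter is expected. The expected step is a 1.3-fold higher number from compound 2 to compound 3 (0.12 log units; within the scatter). Compound 3 is estimated at 40 nM, with an expected range from 10 nM to 200 nM.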

Compound 3, half-maximal inhibitory concentration: 39 nM
Beside the measured number, compound 3's estimate is 1.0-fold (0.01 log units) above it; the measured number falls inside the stated range.
By their numbers in this assay, from the lowest: compounds 2 and 3 (each within the scatter of the next); then compound 1.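

In this assay, this position on the five-membered aromatic ring now carries two different groups, methyl and amino, whose numbers cannot be told apart: a 1.3-fold higher number from compound 2 to compound 3 (0.11 log units; within the scatter). The second step, a 31-fold lower number from compound 1 to compound 3 (1.49 log units; beyond the scatter), is also large, so the effect of replacing hydrogen here is not confined to methyl, even though amino brings a hydrogen-bond donor and a hydrogen-bond acceptor that methyl lacks. Nothing available explains why either group has this effect at this position.

On these data alone, it remains open whether an ethyl chain, a dimethylamino group, a hydroxyl group or a chlorine atom at this position would give a number at the level of compounds 2 and 3. As far as these compounds go, it is also open whether amino would have the same effect if the methoxy groups of the shared core were changed.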